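Aryl swaps on the anilino nitrogen of the shared core

The source may hold more compounds than are shown below. What is called first, only, known or untested is meant among the compounds shown, and "the series" means these compounds.

Measured so far:
- compound 1 `Cc1cc(Nc2cc(N3CCN(C)CC3)nc(Nc3cccc([N+](=O)[O-])c3)n2)n[nH]1`: in a functional assay on DU-145 cells (Homo sapiens) for antiproliferative activity, read by CCK-8 assay, with a stated time of 72 h (on this read-out higher numbers stand for weaker inhibition and lower numbers for stronger inhibition), compound 1 gives 1340 nM
- compound 2 `Cc1cc(Nc2cc(N3CCN(C)CC3)nc(Nc3ccc(S(N)(=O)=O)cc3)n2)n[nH]1`: in this assay compound 2 gives 926 nM

Compound 2 stands alongside compound 1 on the numbers shown: the two values lie within the scatter of each other, so neither is set apart. For the measured compounds named here, the one step measured, a 1.4-fold lower number from compound 1 to compound 2 (0.16 log units; within the scatter), exchanges the aryl group on the same nitrogen of the shared core and leaves the number essentially where it was.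

Compound 3 `COc1cccc(Nc2nc(Nc3cc(C)[nH]n3)cc(N3CCN(C)CC3)n2)c1` continues this line. The change is 3-methoxyphenyl in place of 4-sulfamoylphenyl on a nitrogen on an aromatic ring. Going by the values given here, the only step that bears on it is the step from compound 1 to compound 2, which was within the scatter; with a single such precedent, and both aryl groups so far giving numbers of the same order, no step beyond the scatter is expected in this assay for this further exchange, in either direction. The estimate for compound 3 is therefore 1000 nM, within 400 nM to 2600 nM, meaning an expected step of a 1.1-fold higher number from compound 2 to compound 3 (0.03 log units; within the scatter).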

Compound 3, half-maximal inhibitory concentration: 2650 nM
The estimate for compound 3 lay 2.7-fold (0.42 log units) below the measured number; measured number above the stated range.
By their numbers in this assay, from the lowest: compounds 2, 1 and 3 (each within the scatter of the next, the first and the last beyond it).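

For the compounds shown here, at this position on the shared core, the aryl group can move the number beyond the scatter: in this assay, the exchange of 4-sulfamoylphenyl for 3-methoxyphenyl gives a 2.9-fold higher number from compound 2 to compound 3 (0.46 log units; beyond the scatter), the first such step. This reach is limited, as methoxy in place of nitro on an aromatic carbon gives a 2.0-fold higher number from compound 1 to compound 3 (0.30 log units; within the scatter), which is within the scatter, and compound 1 therefore remains within the scatter of both compound 2 and compound 3. The exchange from compound 2 to compound 3 replaces a group with 1 hydrogen-bond donor and 2 hydrogen-bond acceptors with one with 0 hydrogen-bond donors and 1 hydrogen-bond acceptor, but no available measurement connects these counts or any other feature of the groups to the result.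

Open, going by these compounds, is whether the step follows the identity of the group or its place on the phenyl ring, as both differ between 4-sulfamoylphenyl and 3-methoxyphenyl, and a 3-sulfamoylphenyl group would separate the two. Also open, on these data alone, is how a carboxylic acid or a primary amine on the same ring would read in this assay.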